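This account rests on a few compounds, and the source may have more. Where it says the series, first, only, none or still open, it means among the compounds named here.

Within the data shown here, compound 2 `CS(=O)(=O)c1cnc(O[C@H]2CC[C@H](OC3CCN(CC4(C(F)(F)F)CCC4)CC3)CC2)cn1` stands as the lower of the two numbers so far in a functional assay on isolated protein for agonist activity at Glucose-dependent insulinotropic receptor (Rattus norvegicus), read by HTRF and cAMP accumulation (a higher number here means that more compound is needed for the effect, a lower number that less compound is needed), where compound 2 gives 80 nM. Among the measured compounds shown here, its nearest neighbour is compound 1 `CS(=O)(=O)c1cnc(O[C@H]2CC[C@H](OC3CCN(C(=O)OC4CCOC4)CC3)CC2)cn1`, which in this assay gives 1500 nM; the step of a 19-fold lower number from compound 1 to compound 2 (1.27 log units; beyond the scatter) is the only measured step, and it is large.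

Compound 3 `CC(C)c1noc(CN2CCC(O[C@H]3CC[C@H](Oc4cnc(S(C)(=O)=O)cn4)CC3)CC2)n1` differs from compound 2 in one place: 3-isopropyl-1,2,4-oxadiazol-5-yl in place of 1-(trifluoromethyl)cyclobutyl on a saturated chain carbon bound to an amine nitrogen in a ring. The new group therefore sits on the same saturated chain carbon bound to the ring amine nitrogen that was altered in the step from compound 1 to compound 2. That step bears on the present change only loosely: it showed that the substituent on the ring amine nitrogen can move the number a great deal, but it compared a carbonyl-linked group with a methylene-linked one, whereas the present change keeps the methylene link and exchanges the group behind it. For the measured compounds named here, no measured pair shows a cyclobutyl against an oxadiazolyl at this place.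

Compound 3 is therefore expected near compound 2, with a modest move a 2.5-fold higher number from compound 2 to compound 3 (0.40 log units; beyond the scatter) and wide uncertainty, at an estimated 200 nM with a range from 50 nM to 800 nM.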

Compound 3, half-maximal effective concentration: 97.9 nM
Estimate against measurement, compound 3: 2.0-fold (0.31 log units) above; low and high end bracket the measured number.
By their numbers in this assay, from the lowest: compounds 2 and 3 (each within the scatter of the next); then compound 1.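

In this assay, 3-isopropyl-1,2,4-oxadiazol-5-yl in place of 1-(trifluoromethyl)cyclobutyl on a saturated chain carbon bound to an amine nitrogen in a ring gives a 1.2-fold higher number from compound 2 to compound 3 (0.09 log units; within the scatter), so the two groups cannot be told apart here, although one brings a five-membered aromatic ring with 3 hydrogen-bond acceptors and the other a four-membered carbon ring with 0 hydrogen-bond acceptors. The large step seen earlier is thus not tied to a single group, for the second methylene-linked group also gives a 15-fold lower number from compound 1 to compound 3 (1.19 log units; beyond the scatter), of similar size to a 19-fold lower number from compound 1 to compound 2 (1.27 log units; beyond the scatter), and neither of these two compounds goes against that reading. No measurement at hand accounts for why such different groups read alike.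

On these data alone, it remains open whether a carboxylic acid, a primary amine or a plain longer alkyl chain on the same chain carbon would hold the number or lose it. As far as these compounds go, it is also open which part of the new group matters, as a methyl or a cyclopropyl in place of the isopropyl on the same oxadiazole would begin to show.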